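Inverting one chain stereocentre in the bromo compound

The source may hold more compounds than are shown below. What is called first, only, known or untested is meant among the compounds shown, and "the series" means these compounds.

In an ADME assay on Caco-2 cells (Homo sapiens) for permeability, in the apical to basolateral direction (a higher number here means that the compound crosses the layer faster, a lower number that the compound crosses the layer more slowly), compound 1 (`COC(=O)N[C@H](C(=O)NN(CCC[C@@](O)(Cc1ccccc1)C(=O)N[C@H]1c2ccccc2C[C@H]1O)Cc1ccccc1)C(C)(C)C`) gives < 20 10^-6 cm/s as a limit. Compound 2 (`COC(=O)N[C@H](C(=O)NN(CCC[C@@](O)(Cc1ccccc1)C(=O)N[C@H]1c2ccccc2C[C@H]1O)Cc1ccc(Br)cc1)C(C)(C)C`) gives > 20 10^-6 cm/s and this too is a limit, so its position is known from one side only. Among the measured compounds shown here, the single measured step is a number no lower from compound 1 to compound 2 (the limit leaves the size open) and its size cannot be read. That step is a bromo in place of hydrogen on an aromatic carbon, not a change of configuration.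

Compound 3 (`COC(=O)N[C@H](C(=O)NN(CCC[C@](O)(Cc1ccccc1)C(=O)N[C@H]1c2ccccc2C[C@H]1O)Cc1ccc(Br)cc1)C(C)(C)C`) is the next case (the two compounds have the same atoms and bonds and differ only in configuration as drawn: 1 of 4 stereo elements differ; a stereocentre at a saturated chain carbon is drawn R in compound 2 and S in compound 3). For the measured compounds named here, no measured step covers a change of this kind, so no direction can be argued and no shift beyond the scatter is expected in this assay here. The estimated change is a step that the limit leaves unreadable from compound 2 to compound 3 and no larger. Compound 3 is expected at 25 10^-6 cm/s within an estimated range of 12 10^-6 cm/s to 50 10^-6 cm/s. Compound 3 may also turn out to give only a limit.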

Compound 3, apparent permeability: > 20 10^-6 cm/s
Compound 3 ended at the assay's limit (the forecaster's own chance of this, stated with the estimate: 70%); the middle value lies beyond the limit too.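

In this assay no step can be read between compound 2 and compound 3, since both sit at the same limit: the limit of > 20 10^-6 cm/s in this assay, at which 2 of the 3 values shown sit.

The compounds shown leave open how far either value lies past that limit, and whether inverting the chain stereocentre shifts the read-out at all.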